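The compounds below may be only part of what the source reports. "The series", "measured", "known", "first", "only" and "open" are said of these compounds alone.

Working notes on a small series sharing one core, read in an ADME assay on BHK-21 cells (Mesocricetus auratus) for cytotoxicity, read by MTT assay, with a stated time of 96 h (on this read-out lower numbers stand for higher toxicity in this test and higher numbers for lower toxicity in this test), throughout. Compound 1 (`COc1ccc(/N=N/N2CCCC2)cc1`) gives >= 100000 nM, and this is a limit of the assay, not a number. Compound 2 (`FC(F)(F)c1cccc(/N=N/N2CCCC2)c1`) gives > 100000 nM, which is likewise a limit of the assay. Compound 2 therefore has no numerical position and stands at the limit of > 100000 nM in this assay, at which 1 of the 2 values shown sits. The other reading, for compound 1, stands at the limit of >= 100000 nM in this assay, at which 1 of the 2 values shown sits.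

The next compound is compound 3 (`c1ccc(/N=N/N2CCCC2)cc1`), still unmeasured. Relative to compound 2, the change is hydrogen in place of trifluoromethyl on an aromatic carbon.

Within the data shown here, no measured step gives a size for this change in this assay, so no direction can be taken from the data. The expectation of no shift rests on compound 2 with its limit of > 100000 nM and on the absence of any numerical reading so far. The estimated change is a number no higher from compound 2 to compound 3 (the limit leaves the size open), and it is expected to stay within the usual scatter. For compound 3 the expected value is 100000 nM, with an estimated range from 40000 nM to 150000 nM, and a further limit reading is likely.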

Compound 3, half-maximal cytotoxic concentration: >= 100000 nM
Compound 3: no number, only a limit; the forecaster's own chance of this, stated with the estimate: 75%; the middle value lies on the limit itself.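

Compound 3 gives >= 100000 nM in this assay, which is a limit of the assay and not a number. The steps to compound 3 from compound 1 and from compound 2 cannot be read, as all three readings are limits. The compounds shown leave open whether any change on the shared core produces a numerical reading in this test.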